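The compounds below may be only part of what the source reports. "The series", "measured", "known", "first", "only" and "open" are said of these compounds alone.

Measured so far in a functional assay on EOL1 cells (Homo sapiens) for inhibition, read by fluorescence, with a stated time of 72 h; a higher number here means a weaker inhibitor of growth, a lower number a stronger inhibitor of growth (two compounds):
- compound 1 `COc1ccc(Cn2cnc3c(Nc4cccc(Cl)c4)nc(N[C@H]4CC[C@H](N)CC4)nc32)cc1` gives 530 nM
- compound 2 `CC(C)CCn1cnc2c(NCc3cccc(Cl)c3)nc(N[C@H]3CC[C@H](N)CC3)nc21` gives 1330 nM

Compound 1 at 530 nM holds the lower of the two numbers, and compound 2 at 1330 nM lies higher by more than the scatter. Next in line is compound 3 `CCCCCCn1cnc2c(Nc3cccc(Cl)c3)nc(N[C@H]3CC[C@H](N)CC3)nc21`, not yet measured. It carries pentyl in place of 4-methoxyphenyl on a saturated chain carbon bound to an aromatic nitrogen, which, cut one bond further out, reads 4-methoxybenzyl to hexyl. Among the measured compounds shown here, no measured pair isolates this change, so the direction rests on little evidence. A moderate move toward a higher number in this assay is expected, though no step beyond the scatter remains possible, and the expected step is a 1.6-fold higher number from compound 1 to compound 3 (0.21 log units; within the scatter) in size. The estimated value for compound 3 is 850 nM with an expected range of 300 nM to 2400 nM around it.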

Compound 3, concentration for 50% growth inhibition: 310 nM
Compound 3: middle estimate off by 2.7-fold (0.44 log units), on the high side; low and high end bracket the measured number.
By their numbers in this assay, from the lowest: compounds 3 and 1 (each within the scatter of the next); then compound 2.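

In this assay, on a saturated chain carbon bound to an aromatic nitrogen, pentyl in place of 4-methoxyphenyl gives a 1.7-fold lower number from compound 1 to compound 3 (0.23 log units; within the scatter) and so does not separate the two groups. For these two compounds, the six-membered aromatic ring and the hydrogen-bond acceptor that leave with 4-methoxyphenyl are not needed to keep the number in this range, and a chain without a ring serves as well. Nothing at hand explains why the two groups read alike.

Still open, going by these compounds, is how a shorter chain such as ethyl or a longer chain such as octyl reads at this position. Also open, on these data alone, is whether a hexyl chain carrying an amine or a carboxylic acid, or a benzyl group without the methoxy, stays in the same range.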